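Trimming the hydrazone arm of compound 2

The compounds below may be only part of what the source reports. "The series", "measured", "known", "first", "only" and "open" are said of these compounds alone.

Of the compounds shown here, three built on one shared core have been measured in a functional assay on HeLa cells (Homo sapiens) for inhibition, read by MTT assay, with a stated time of 48 h; on this read-out higher numbers stand for weaker inhibition and lower numbers for stronger inhibition. Compound 1 `CCOC(=O)C1=C(N/C=N/c2nnc(S(N)(=O)=O)s2)Nc2[nH]nc(C)c2C1c1ccc(N(C)C)cc1` gives 26300 nM. Compound 2 `CCOC(=O)C1=C(N/N=C(/C(=O)Br)c2ccc(Br)cc2)Nc2[nH]nc(C)c2C1c1ccc(N(C)C)cc1` gives 68500 nM, and compound 3 `CCOC(=O)C1=C(N/C=N/c2ccc(C)cc2)Nc2[nH]nc(C)c2C1c1ccc(N(C)C)cc1` gives 43200 nM. Compound 2 stands at the highest of the three numbers: there is a 2.6-fold higher number from compound 1 to compound 2 (0.42 log units; beyond the scatter), whereas there is a 1.6-fold lower number from compound 2 to compound 3 (0.20 log units; within the scatter), and between the other pair there is a 1.6-fold higher number from compound 1 to compound 3 (0.22 log units; within the scatter).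

Compound 4 `CCOC(=O)C1=C(N/N=C(/Cl)C#N)Nc2[nH]nc(C)c2C1c1ccc(N(C)C)cc1` has not yet been measured in this assay. Set against compound 2, the change is a group of 5 heavy atoms (2 carbon, 2 nitrogen, 1 chlorine; no ring) in place of a group of 12 heavy atoms (8 carbon, 1 nitrogen, 1 oxygen, 2 bromine; one six-membered aromatic ring of carbon only), on an amine nitrogen. Within the data shown here, two measured steps touch the same amine nitrogen: the one from compound 1 to compound 2 and the one from compound 2 to compound 3. Both exchanged one sizeable group for another, and neither moved the number by more than a modest amount. Among the measured compounds shown here, no measured step replaces a ring-bearing group with one as small as the group entering compound 4, so the expectation leans on that modest span. The number for compound 4 is therefore expected to stay close to that of compound 2, or to come out somewhat lower, with a 1.7-fold lower number from compound 2 to compound 4 (0.23 log units; within the scatter). Compound 4 is estimated at 40000 nM, within a range of 15000 nM to 110000 nM.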

Compound 4, half-maximal inhibitory concentration: 26200 nM
Estimate against measurement, compound 4: 1.5-fold (0.18 log units) above; the range from low to high includes it.
By their numbers in this assay, from the lowest: compounds 4, 1, 3 and 2 (each within the scatter of the next, the first and the last beyond it).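

On the amine nitrogen whose other neighbour is the double-bonded ring carbon, the aromatic ring is not needed to keep the number in this assay where it was: the smallest group so far, with no ring, gives a 2.6-fold lower number from compound 2 to compound 4 (0.42 log units; beyond the scatter), a modest step and the first from compound 2 to a ring-free group. The same group stands level with both other arms, with a 1.6-fold lower number from compound 3 to compound 4 (0.22 log units; within the scatter) and a 1.0-fold lower number from compound 1 to compound 4 (0.00 log units; within the scatter), so it cannot be told apart from the carbon-only aromatic ring of compound 3 or the five-membered aromatic ring of compound 1. Group size does not order these four compounds, as compound 1, with a much larger group, matches compound 4, and only compound 2 lies beyond the scatter of any other compound, and then only of compounds 1 and 4.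

The compounds shown do not separate the chlorine from the nitrile in the entering group, and they leave open how a small group such as a methyl, an amine or a carboxylic acid would read at this nitrogen. No measurement shown accounts for the step from compound 2.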